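Metabolic stability in a pyrazole-fused sulfonamide series

A few compounds are considered here, and "the series" means these few. Any claim that something is new, unique, unknown or untested is made for them only; others in the source may bear on it.

Measured compounds:
compound 1, `O=S(=O)(c1ccc(Cl)cc1)N1CCc2n[nH]cc2C1CO`, 84%
compound 2, `O=S(=O)(c1ccc(Cl)cc1)N1Cc2c[nH]nc2CC1c1ccccc1`, 5%

In an ADME assay on microsomes from liver (Homo sapiens) for metabolic stability, using NADPH, with a stated time of 30 min, in the presence of a further agent that is not named here (a lower number here means that less of the compound is left, a higher number that more of the compound is left), compound 1 gives 84%. Compound 2, which carries a phenyl group on the shared core, gives 5% in this assay. Compound 2 therefore stands lowest of the two numbers measured, and the gap to compound 1 is far beyond the scatter of repeated measurements. Among the measured compounds shown here, no single-point step between measured compounds is available, so the two values can only be set side by side.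

The next compound, compound 3, `O=S(=O)(c1ccc(Cl)cc1)N1Cc2c[nH]nc2CC1c1ccc(Cl)cc1`, differs from compound 2 in one place: chloro in place of hydrogen on an aromatic carbon. Cut one bond further out, the same difference reads phenyl to 4-chlorophenyl.

Nothing measured here speaks to the effect of a chloro group on this ring, so the expectation rests on the position of compound 2 alone. Compound 2 already sits near the floor of the read-out, and the small structural change is expected to move the number little, with the step from a number 3 percentage points higher from compound 2 to compound 3 (within the scatter) judged to lie within the scatter. Compound 3 is thus estimated at 8%, between 1% and 28%.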

Compound 3, percent of the compound remaining: 12%
The estimate for compound 3 lay 4 percentage points below the measured number; the measured number falls inside the stated range.
By their numbers in this assay, from the lowest: compounds 2 and 3 (each within the scatter of the next); then compound 1.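

In this assay, among the compounds shown here, chloro in place of hydrogen on an aromatic carbon, para to a large group, gives a number 7 percentage points higher from compound 2 to compound 3 (within the scatter), and this is the first step that can be read at a single place. The change from phenyl to 4-chlorophenyl therefore does not separate the two compounds in this read-out: compound 2 gives 5% and compound 3 gives 12%, so at this position chloro leaves the number in the same range as hydrogen. No measurement shown here offers an explanation for this result.

On these data alone, whether a different group on this ring at the same position, such as an amine, a carboxylic acid or a longer chain, would give a number beyond the scatter of compound 2 remains open, as does the outcome of chloro elsewhere on the ring. The much higher number of compound 1, at 84%, cannot be assigned to any one structural feature, since compound 1 differs from compound 2 and compound 3 in more than one place.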